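Phenyl for thiophene beside the nitrile

This account rests on a few compounds, and the source may have more. Where it says the series, first, only, none or still open, it means among the compounds named here.

Measured compounds:
compound 1, `COc1ccc(-c2c(C#N)c(-c3ccccc3)nc3c2c(-c2ccccc2)nn3-c2ccccc2)cc1OC`, > 25000 nM
compound 2, `COc1cc(-c2c(C#N)c(-c3cccs3)nc3c2c(-c2ccccc2)nn3-c2ccccc2)ccc1O`, 15400 nM

Going by the values given here, in a functional assay on K562 cells (Homo sapiens) for antiproliferative activity, read by resazurin assay, with a stated time of 72 h (on this read-out lower numbers stand for stronger inhibition and higher numbers for weaker inhibition), compound 2 gives 15400 nM, the only proper number in this small set. For compound 1 the result > 25000 nM is a limit of the assay and not a number. Compound 3 `COc1cc(-c2c(C#N)c(-c3ccccc3)nc3c2c(-c2ccccc2)nn3-c2ccccc2)ccc1O` is not yet measured. It differs from compound 2 by phenyl in place of thiophen-2-yl on an aromatic carbon. Among the compounds with values here, no measured pair isolates this change, so the size of the step rests on indirect reading. Compound 1 also carries the phenyl at this carbon and stands at the limit of > 25000 nM in this assay, at which 1 of the 2 values shown sits, though its other aryl group differs. On that basis the step of a 1.4-fold higher number from compound 2 to compound 3 (0.15 log units; within the scatter) is expected to run toward weaker inhibition, possibly past the scatter. Compound 3 is estimated at 22000 nM, with a range from 8000 nM to 60000 nM and a fair chance of a limit only.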

Compound 3, half-maximal inhibitory concentration: > 50000 nM
Compound 3: only a limit was reported (the forecaster's own chance of this, stated with the estimate: 45%); middle value at least 2.2-fold (0.35 log units) from the limit.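

In this assay, the change from thiophen-2-yl to phenyl on this aromatic carbon, next to the ring nitrogen and ortho to a cyano group, now has a direct pair, and it gives an at least 3.2-fold higher number from compound 2 to compound 3 (0.51 log units; beyond the scatter). For compound 3 the result is a limit of the assay and not a number: the limit of > 50000 nM in this assay, at which 1 of the 3 values shown sits. The step between compound 1 and compound 3 cannot be read, as both results are limits.

The compounds shown test this exchange only with the 4-hydroxy-3-methoxyphenyl group in place, so its size with another aryl group stays open, as does its full size in this pair. At this carbon they hold only thiophen-2-yl and phenyl, which leaves open how a primary amine or a carboxylic acid would read.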